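A few compounds are considered here, and "the series" means these few. Any claim that something is new, unique, unknown or untested is made for them only; others in the source may bear on it.

Three measured compounds share one core, and all were tested in an assay for inhibition of MAP kinase-interacting serine/threonine-protein kinase 2 (Homo sapiens), read by luminescence and ADP-Glo, with a stated time of 2 h; on this read-out higher numbers stand for weaker inhibition and lower numbers for stronger inhibition. Compound 1 `CC(=O)Nc1cccc(Cn2cc(-c3ccc4cn[nH]c4c3)ccc2=O)c1` gives 43 nM. Compound 2 `O=c1ccc(-c2ccc3cn[nH]c3c2)cn1Cc1cccc(C(F)(F)F)c1` gives 32 nM, so that the change from compound 1 to compound 2, trifluoromethyl in place of acetamido on an aromatic carbon, produced a 1.3-fold lower number from compound 1 to compound 2 (0.13 log units; within the scatter). Compound 3 `CC(=O)Nc1cccc(Cn2cc(-c3ccc4c(N)n[nH]c4c3)ccc2=O)c1` gives 8 nM, and the change from compound 1 to compound 3, amino in place of hydrogen on an aromatic carbon, produced a 5.4-fold lower number from compound 1 to compound 3 (0.73 log units; beyond the scatter). Among the three, compound 3 stands at the lowest number, that is the strongest inhibition, with compound 2 nearest and compound 1 furthest, both gaps beyond the scatter.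

Compound 4 `Nc1n[nH]c2cc(-c3ccc(=O)n(Cc4cccc(C(F)(F)F)c4)c3)ccc12` has not yet been measured. It differs from compound 3 in one place: trifluoromethyl in place of acetamido on an aromatic carbon. This is the same exchange already seen between compound 1 and compound 2, where it gave only a 1.3-fold lower number from compound 1 to compound 2 (0.13 log units; within the scatter), a step within the scatter. Among the measured compounds shown here, nothing among the measured compounds suggests that the amino group of compound 3 alters the effect of this exchange, so in this assay no step beyond the scatter is expected, at most a slight move toward a lower number, which as a step would read a 1.3-fold lower number from compound 3 to compound 4 (0.12 log units; within the scatter). For compound 4 the expected value is therefore 6 nM, with a likely range from 2.5 nM to 15 nM.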

Compound 4, half-maximal inhibitory concentration: 21 nM
For compound 4 the middle estimate is 3.5-fold (0.54 log units) below the measured one, outside the stated range (above it).
By their numbers in this assay, from the lowest: compound 3; then compounds 4, 2 and 1 (each within the scatter of the next, the first and the last beyond it).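

Trifluoromethyl and acetamido on this aromatic carbon, meta to a large group, are interchangeable only on the core without the amino group; on the amino-bearing core, the exchange gives a 2.6-fold higher number from compound 3 to compound 4 (0.42 log units; beyond the scatter). The outcome of this one change therefore depends on the rest of the molecule: the same change on two cores in this assay, a 1.3-fold lower number (0.13 log units; within the scatter) from compound 1 to compound 2 and a 2.6-fold higher number (0.42 log units; beyond the scatter) from compound 3 to compound 4, 3.5-fold (0.55 log units) apart, beyond the scatter of two such steps. Read the other way, the amino group pays off clearly with acetamido in place, but with trifluoromethyl the step is only a 1.5-fold lower number from compound 2 to compound 4 (0.18 log units; within the scatter), so the two changes do not simply add up across these four compounds: the same change on two cores in this assay, a 5.4-fold lower number (0.73 log units; beyond the scatter) from compound 1 to compound 3 and a 1.5-fold lower number (0.18 log units; within the scatter) from compound 2 to compound 4, 3.5-fold (0.55 log units) apart, beyond the scatter of two such steps.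

These compounds leave open what in acetamido goes with the amino group, and whether a smaller amide, a methoxy group or a carboxylic acid at the same place would keep the lower number of compound 3 or fall in with compound 4. They also leave open whether a methyl or a methylamino group in place of the amino group would show the same dependence on the group at this place.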